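Aryl variation on the ring nitrogen: cytotoxicity notes

The compounds below may be only part of what the source reports. "The series", "measured", "known", "first", "only" and "open" are said of these compounds alone.

Compound 3 `COc1ccc(-n2c(=O)n(Cc3cc4cc(Cl)ccc4n3CCCC#N)c3cnccc32)cc1C` carries a 4-methoxy-3-methylphenyl group on an aromatic nitrogen of the shared core. In an ADME assay on HeLa cells (Homo sapiens) for cytotoxicity, read by ATP content, with a stated time of 3 days (on this read-out higher numbers stand for lower toxicity in this test and lower numbers for higher toxicity in this test), compound 3 reaches only a limit, > 50000 nM. Its two neighbours behave alike. Compound 1 `N#CCCCn1c(Cn2c(=O)n(-c3ncco3)c3ccncc32)cc2cc(Cl)ccc21` bears 1,3-oxazol-2-yl at that nitrogen; in this assay compound 1 gives only a limit, > 50000 nM. Compound 2 `CS(=O)(=O)c1ccc(-n2c(=O)n(Cc3cc4cc(Cl)ccc4n3CCCC#N)c3cnccc32)cc1` bears 4-(methylsulfonyl)phenyl there; in this assay compound 2 likewise gives only a limit, > 50000 nM. All three values rest at the limit of > 50000 nM in this assay, at which 3 of the 3 values shown sit, so the steps a step that the two limits leave unreadable from compound 1 to compound 2, a step that the two limits leave unreadable from compound 1 to compound 3 and a step that the two limits leave unreadable from compound 2 to compound 3 cannot be sized or given a direction.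

Compound 4 `COc1ccc(-n2c(=O)n(Cc3cc4cc(Cl)ccc4n3CCCC#N)c3cnccc32)c(F)c1` differs from compound 3 in one place: 2-fluoro-4-methoxyphenyl in place of 4-methoxy-3-methylphenyl on an aromatic nitrogen. The measured steps that bear on this change are the three aryl and heteroaryl swaps on the same nitrogen, none readable because every value sits at the limit of > 50000 nM in this assay, at which 3 of the 3 values shown sit. The step that the limit leaves unreadable from compound 3 to compound 4 is therefore expected to stay within the scatter. Compound 4 is estimated at 60000 nM in this assay, with a range from 20000 nM to 200000 nM, most likely again reported only as a limit.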

Compound 4, half-maximal cytotoxic concentration: > 50000 nM
Compound 4: no number, only a limit; the forecaster's own chance of this, stated with the estimate: 85%; the middle value lies beyond the limit too.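

Compound 4 gives only a limit as well, so none of its steps from compound 1, compound 2 or compound 3 can be read: the limit of > 50000 nM in this assay, at which 4 of the 4 values shown sit.

From the compounds shown here alone, whether any group on that aromatic nitrogen changes the outcome in this assay remains open.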